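Hydroxy in Place of Chloro: Expected Paw Edema Inhibition

The source may report more compounds than this note shows. Statements on the series, on what has been measured and on what is new or still open speak of the compounds shown alone.

Compound 1, `N#Cc1c(Nc2ccc(O)cc2)nc(SCC(=O)Nn2c(COc3ccc(Cl)cc3Cl)nc3ccccc3c2=O)nc1-c1ccc(Cl)cc1`: 91.2%
Compound 2, `N#Cc1c(Nc2ccccc2)nc(SCC(=O)Nn2c(COc3ccc(Cl)cc3Cl)nc3ccccc3c2=O)nc1-c1ccc(O)cc1`: 91.2%
Compound 3, `N#Cc1c(Nc2ccc(Cl)cc2)nc(SCC(=O)Nn2c(COc3ccc(Cl)cc3Cl)nc3ccccc3c2=O)nc1-c1ccc(O)cc1`: 79%

In a functional assay on the whole organism (strain albino) for inhibition, with Rattus norvegicus as the target, read by paw edema, with stated times of 1 h and 3 h, at a dose of 100 mg/kg by the oral route (on this read-out lower numbers stand for a weaker effect and higher numbers for a stronger effect at the one dose given), compound 3 stands lowest of the three measured compounds; compound 1 and compound 2 each give a number higher by more than the usual scatter. Compound 4, `N#Cc1c(Nc2ccc(O)cc2)nc(SCC(=O)Nn2c(COc3ccc(Cl)cc3Cl)nc3ccccc3c2=O)nc1-c1ccc(O)cc1`, has not yet been measured. It differs from compound 3 by hydroxy in place of chloro on an aromatic carbon.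

Among the compounds with values here, one measured step bears directly on this change: a number 12.2 percentage points lower from compound 2 to compound 3 (beyond the scatter), a modest drop when chloro entered at this place. Within the data shown here, no measured pair compares hydroxy with chloro at this place. Compound 1, which also carries (4-hydroxyphenyl)amino, gives the same number as compound 2, and the two lie within the scatter of each other, so nothing can be said about order between them.

Taking chloro away is expected to recover much of the ground lost because a number 12.2 percentage points lower from compound 2 to compound 3 (beyond the scatter), so a modest rise of a number 10 percentage points higher from compound 3 to compound 4 (within the scatter) is expected. Compound 4 is estimated at 89%, within 79% to 96%.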

Compound 4, a percentage reported as inhibition, in the whole organism at one dose (the size of the read-out at that dose, not a potency): 86.8%
Compound 4: the middle estimate sits 2.2 percentage points above what was measured, within the range that was stated.
By their numbers in this assay, from the lowest: compounds 3, 4, 1 and 2 (each within the scatter of the next, the first and the last beyond it).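

In this assay, within the data shown here, the step of a number 7.8 percentage points higher from compound 3 to compound 4 (within the scatter) is the first direct comparison of (4-chlorophenyl)amino with (4-hydroxyphenyl)amino, and it does not separate the two groups. The step of a number 4.4 percentage points lower from compound 2 to compound 4 (within the scatter) puts hydroxy in place of hydrogen at the same place, so compound 4 lies within the scatter of both compound 2 and compound 3, even though those two lie beyond the scatter of each other. Going from 4-chlorophenyl to 4-hydroxyphenyl gives a number 4.4 percentage points lower from compound 1 to compound 4 (within the scatter) and likewise shows no readable difference. Nothing available explains these results.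

The compounds shown leave open how a methoxy group or an amine would compare at this place. With a single dose, they also leave open whether compounds 1, 2 and 4 would separate at lower doses.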